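The source may hold more compounds than are shown below. What is called first, only, known or untested is meant among the compounds shown, and "the series" means these compounds.

In an assay on isolated protein for inhibition of thyroid hormone receptor alpha (Homo sapiens), read by fluorescence polarization (a higher number here means a weaker inhibitor, a lower number a stronger inhibitor), three compounds have been measured so far, and every one of them returns only a limit of the assay rather than a number:

compound 1 `Cc1ccc(N2CCN(C(=O)C3CCN(C(=O)c4ccc(S(C)(=O)=O)c([N+](=O)[O-])c4)CC3)CC2)cc1`: > 60000 nM
compound 2 `CS(=O)(=O)c1ccc(C(=O)N2CCC(C(=O)N3CCc4ccccc4C3)CC2)cc1[N+](=O)[O-]`: > 60000 nM
compound 3 `CC(C)N(C(=O)C1CCN(C(=O)c2ccc(S(C)(=O)=O)c([N+](=O)[O-])c2)CC1)C(C)C`: > 60000 nM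

Compound 3 therefore stands at the limit of > 60000 nM in this assay, at which 3 of the 3 values shown sit, with no number of its own, and the same holds for the two other compounds shown. Going by the values given here, the only single-point step among the measured compounds, a step that the two limits leave unreadable from compound 2 to compound 3, cannot be read because both ends sit at that limit, so its size and direction remain unknown. Compound 4 `CN1CCN(C(=O)C2CCN(C(=O)c3ccc(S(C)(=O)=O)c([N+](=O)[O-])c3)CC2)CC1` differs from compound 3 by 4-methylpiperazin-1-yl in place of diisopropylamino on a carbonyl carbon. No measured step bears on this change in a readable way, so no size of step in this assay can be derived from the data shown. The step that the limit leaves unreadable from compound 3 to compound 4 is therefore expected to leave compound 4 at the limit as well, not beyond the scatter. Compound 4 is estimated at 80000 nM, with a range from 20000 nM to 400000 nM.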

Compound 4, half-maximal inhibitory concentration: > 60000 nM
Compound 4: only a limit was reported (the forecaster's own chance of this, stated with the estimate: 85%); the middle value does not contradict the limit.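

No new step can be read, since the steps from compound 1, compound 2 and compound 3 to compound 4 all end at a limit of the assay, not at a number: the limit of > 60000 nM in this assay, at which 4 of the 4 values shown sit.

The compounds shown leave open whether any change to the shared core gives a measurable value in this assay.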